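The source may report more compounds than this note shows. Statements on the series, on what has been measured and on what is new or still open speak of the compounds shown alone.

Compound 1 `CC(=O)/C(=N\c1ccccc1)NNc1ccccc1C` and compound 2 `CC(=O)/C(=N\c1cccc(C(F)(F)F)c1)NNc1ccccc1C` share a core and differ only where a trifluoromethyl gives way to a hydrogen (hydrogen in place of trifluoromethyl on an aromatic carbon). In an assay on isolated protein for binding affinity to corticotropin-releasing factor receptor 1 (Homo sapiens) (on this read-out higher numbers stand for weaker inhibition and lower numbers for stronger inhibition), compound 2 gives 291 nM, and compound 1 gives 526 nM; the step of a 1.8-fold higher number from compound 2 to compound 1 (0.26 log units; within the scatter) is small. Compound 3 `CC(=O)/C(=N\c1ccccc1Cl)NNc1ccccc1C(F)(F)F` reaches only a limit of this assay, namely > 10000 nM, so that for compound 3 the read-out is a limit and not a number (the limit of > 10000 nM in this assay, at which 1 of the 3 values shown sits). How the core of compound 3 differs from the core of compound 2 is not broken down here. Compound 4 `CC(=O)/C(=N\c1ccccc1Cl)NNc1ccccc1` is not yet measured, and it arises from compound 3 by the same kind of change (hydrogen in place of trifluoromethyl on an aromatic carbon), though the place is not identical: in the pair of compound 2 and compound 1 the carbon is meta to a large group, whereas here it is ortho to a large group. Since the measured pair moved little, compound 4 is expected at 4000 nM, between 600 nM and 15000 nM, a step of an at least 2.5-fold lower number from compound 3 to compound 4 (0.39 log units; beyond the scatter) that is an estimate only, because compound 3 starts from a limit (the limit of > 10000 nM in this assay, at which 1 of the 3 values shown sits).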

Compound 4, inhibition constant: > 10000 nM
Compound 4 gave a limit, no number; the forecaster's own chance of this, stated with the estimate: 35%; middle value at least 2.5-fold (0.39 log units) away from the limit.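

Compound 3 and compound 4 both stop at a limit in this assay rather than giving a number, so the change from trifluoromethyl to hydrogen between them cannot be sized: the limit of > 10000 nM in this assay, at which 2 of the 4 values shown sit. The compounds shown leave open how strongly either compound binds, and whether this change has any effect on an aromatic carbon ortho to a large group.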